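This account rests on a few compounds, and the source may have more. Where it says the series, first, only, none or still open, it means among the compounds named here.

Compound 1 `CCOC(=O)c1c(C(F)(F)F)[n+]([O-])c2ccc(C(F)(F)F)cc2[n+]1[O-]`: 4200 nM
Compound 2 `CCOC(=O)c1c(C(F)(F)F)[n+]([O-])c2ccc(C)cc2[n+]1[O-]`: 7000 nM
Compound 3 `COC(=O)c1c(C(F)(F)F)[n+]([O-])c2ccc(C(F)(F)F)cc2[n+]1[O-]`: 4000 nM

All three were tested in an ADME assay on J774 cells (Mus musculus) for cytotoxicity, read by MTT assay, with a stated time of 48 h; a higher number here means a weaker inhibitor, a lower number a stronger inhibitor. Compound 3 gives the lowest of the three numbers, yet compound 1 and compound 2 both lie within the scatter of it, so the three cannot be put in any order. Compound 4 `COC(=O)c1c(C(F)(F)F)[n+]([O-])c2ccccc2[n+]1[O-]` has not been measured; it differs from compound 3 in one place: hydrogen in place of trifluoromethyl on an aromatic carbon. The step that bears on this is a 1.7-fold higher number from compound 1 to compound 2 (0.22 log units; within the scatter), where a trifluoromethyl on an aromatic carbon gave way to methyl. Replacing that trifluoromethyl by hydrogen is a change of the same kind and place, and the comparable step lay within the scatter, so no step beyond the scatter is expected: a 1.3-fold higher number from compound 3 to compound 4 (0.10 log units; within the scatter). Compound 4 is therefore estimated at 5000 nM, between 2500 nM and 10000 nM.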

Compound 4, half-maximal inhibitory concentration: 19000 nM
The estimate for compound 4 lay 3.8-fold (0.58 log units) below the measured number; the measured number lies above the stated range.
By their numbers in this assay, from the lowest: compounds 3, 1 and 2 (each within the scatter of the next); then compound 4.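

Hydrogen in place of trifluoromethyl on this aromatic carbon gives a 4.8-fold higher number from compound 3 to compound 4 (0.68 log units; beyond the scatter) in this assay, so this position is not indifferent to change. Trifluoromethyl to methyl gave only a 1.7-fold higher number from compound 1 to compound 2 (0.22 log units; within the scatter) on the ethyl ester, so the two replacements of trifluoromethyl differ in what they show: one step is readable and the other is not. Nothing available here explains this step.

Still open, as far as these compounds go, is how an amine or a chlorine atom on this carbon would read. From the compounds shown here alone, it is also open whether hydrogen would give a similar step from compound 1.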